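The source may report more compounds than this note shows. Statements on the series, on what has been measured and on what is new or still open speak of the compounds shown alone.

Measured so far:
- Compound 1, `CC1CCN(C2CCN(S(=O)(=O)c3ccc(F)cc3F)CC2)CC1`: 102 nM
- Compound 2, `CC1CCN(C2CCN(S(=O)(=O)c3cccc(-c4ccc5ccccc5c4)c3)CC2)CC1`: 2 nM
- Compound 3, `CC1CCN(C2CCN(S(=O)(=O)c3cccc(-c4ccccc4)c3)CC2)CC1`: 2 nM

All three share the same core and differ only in the aryl group carried on the sulfonyl sulfur. In a functional assay on DLD-1 cells (Homo sapiens) for antiproliferative activity, read by CellTiter-Glo, with a stated time of 72 h (a higher number here means a weaker inhibitor, a lower number a stronger inhibitor), compound 1 gives the highest of the three numbers, far beyond the scatter from both compound 2 and compound 3, which sit at the same figure as each other. The step of no change at the digits printed from compound 2 to compound 3 (within the scatter) shows that exchanging one aryl substituent for another at that position left the result unchanged.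

Compound 4, `CC1CCN(C2CCN(S(=O)(=O)c3ccc(Br)c(Cl)c3)CC2)CC1`, has not yet been measured. Its change from compound 1 is 4-bromo-3-chlorophenyl in place of 2,4-difluorophenyl on a sulfonyl sulfur. For the measured compounds named here, no measured step exactly matches this change, since the two 3-aryl compounds add a whole ring rather than swapping halogens. Still, compound 1 is the outlier, and every other aryl variant seen so far sits well below it, so the expectation is that compound 4 also moves toward lower numbers, though by less than a full ring would. The expected step is a 6.8-fold lower number from compound 1 to compound 4 (0.83 log units; beyond the scatter). Compound 4 is therefore estimated at 15 nM, in the range 4 nM to 60 nM.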

Compound 4, half-maximal inhibitory concentration: 12 nM
Compound 4: the middle estimate sits 1.3-fold (0.10 log units) above what was measured; measured number inside the range.
By their numbers in this assay, from the lowest: compounds 2 and 3 (each within the scatter of the next); then compound 4; then compound 1.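

In this assay, the step of an 8.5-fold lower number from compound 1 to compound 4 (0.93 log units; beyond the scatter) shows that this position on the sulfonyl sulfur can give a lower number without any added ring. The 4-bromo-3-chlorophenyl group has the same count of 8 heavy atoms as the 2,4-difluorophenyl group it replaces, and each is one six-membered aromatic ring of carbon only, so exchanging the halogens and their places on that ring is enough to move the result beyond the scatter. No measurement at hand explains why this exchange has that effect.

The compounds shown leave open whether the chlorine or the bromine matters more, as the two enter together. From the compounds shown here alone, how a methoxy group or an amine on this ring would read also remains open.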